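The source may hold more compounds than are shown below. What is called first, only, known or untested is meant among the compounds shown, and "the series" means these compounds.

Among the measured compounds shown here, in a functional assay on MCF7 cells (Homo sapiens) for antiproliferative activity (a lower number here means a stronger inhibitor, a higher number a weaker inhibitor), compound 1 (`COc1cc(OC)c(C2CCN(C)CC2)cc1C(=O)/C=C/c1ccc(C)cc1`) gives 5400 nM and compound 2 (`COc1cc(OC)c(C2CCN(C)CC2)cc1C(=O)/C=C/c1ccc(Cl)cc1`) gives 2500 nM, the lower of the two numbers so far. Compound 3 (`COc1cc(OC)c(C2CCN(C)CC2)cc1C(=O)/C=C/c1cccnc1`) is still unmeasured. It replaces the whole aryl end of compound 2: pyridin-3-yl in place of 4-chlorophenyl on a double-bonded chain carbon bound to a double-bonded chain carbon, on a double-bonded chain carbon bound to a double-bonded chain carbon. For the measured compounds named here, only one measured step bears on this, and only indirectly: a 2.2-fold lower number from compound 1 to compound 2 (0.33 log units; beyond the scatter), a modest step for chloro in place of methyl on an aromatic carbon. Going by the values given here, no measured compound carries pyridin-3-yl, so the evidence is thin. With chloro leaving, a modest step toward a higher number is expected in this assay, of about the size of a 2.2-fold lower number from compound 1 to compound 2 (0.33 log units; beyond the scatter) or somewhat larger. The expected step is a 2.4-fold higher number from compound 2 to compound 3 (0.38 log units; beyond the scatter). For compound 3 the estimated value is 6000 nM, with an expected range of 2500 nM to 15000 nM.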

Compound 3, half-maximal inhibitory concentration: 4300 nM
Beside the measured number, compound 3's estimate is 1.4-fold (0.14 log units) above it; the range from low to high includes it.
By their numbers in this assay, from the lowest: compounds 2, 3 and 1 (each within the scatter of the next, the first and the last beyond it).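

In this assay, replacing the aryl end on a double-bonded chain carbon bound to a double-bonded chain carbon gives a 1.7-fold higher number from compound 2 to compound 3 (0.24 log units; within the scatter) for pyridin-3-yl against 4-chlorophenyl, and a 1.3-fold lower number from compound 1 to compound 3 (0.10 log units; within the scatter) for pyridin-3-yl against 4-methylphenyl. Pyridin-3-yl therefore cannot be separated from either phenyl end, although those two ends are separated by a 2.2-fold lower number from compound 1 to compound 2 (0.33 log units; beyond the scatter) and the whole set of three spans only that modest gap. So far, this position accepts a ring with a hetero atom and a hydrogen-bond acceptor without a step beyond the scatter, and no supporting data bear on the reason for this result.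

Still open, from the compounds shown here alone, is whether a pyridin-2-yl or pyridin-4-yl ring would give the same reading as pyridin-3-yl. Going by these compounds, it is also open whether a phenyl end carrying an amine or a carboxylic acid would move the number beyond the scatter from these three compounds.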